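Placing a 4-methoxyphenyl on the Thiocarbonyl Nitrogen

The source may hold more compounds than are shown below. What is called first, only, known or untested is meant among the compounds shown, and "the series" means these compounds.

Of the compounds shown here, three of one shared core have been tested in a functional assay on HT-29 cells (Homo sapiens) for antiproliferative activity, read by sulforhodamine B assay, with a stated time of 72 h; on this read-out lower numbers stand for stronger inhibition and higher numbers for weaker inhibition. Within the data shown here, compound 1 `NC(=S)N/N=C/c1ccc2ccccc2n1` is the only one to give a number: in this assay compound 1 gives 100000 nM. Compound 2 `NC(=S)N/N=C/c1nc2ccccc2s1` is reported only as a limit of the assay in this assay, namely > 100000 nM. Compound 3 `NC(=S)N/N=C/c1cnc2ccccc2n1` likewise reaches only a limit in this assay, > 100000 nM. So two of the three results sit at the limit (the limit of > 100000 nM in this assay, at which 2 of the 3 values shown sit), and compound 1 stands alone as the one measured value, itself very weak.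

Compound 4 `COc1ccc(NC(=S)N/N=C/c2ccc3ccccc3n2)cc1` has not yet been measured. It differs from compound 1 in one place: 4-methoxyphenyl in place of hydrogen on an amide-type nitrogen. Among the measured compounds shown here, no pair of measured compounds shows what such a change does, so the size of the step is open. Compound 4 is expected to be a stronger inhibitor than compound 1, with an estimated step of a 13-fold lower number from compound 1 to compound 4 (1.10 log units; beyond the scatter), well beyond the scatter. The estimate for compound 4 in this assay is 8000 nM, within a range from 1000 nM to 60000 nM.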

Compound 4, half-maximal inhibitory concentration: 82300 nM
Estimate against measurement, compound 4: 10-fold (1.01 log units) below; measured number above the stated range.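

Putting 4-methoxyphenyl in place of hydrogen on the amide-type nitrogen gives, in this assay, a 1.2-fold lower number from compound 1 to compound 4 (0.08 log units; within the scatter), so the two compounds cannot be told apart. Among these compounds, this is the first reading at this nitrogen, and it shows that a group of this size, with its aromatic ring, can sit there without any measurable effect in either direction. It brings no real potency either, and the series as shown stays at the weak end of the scale, where several of the results are only a limit of the assay: the limit of > 100000 nM in this assay, at which 2 of the 4 values shown sit.

A single substituent cannot show whether this nitrogen matters in general, so a plain methyl, a longer alkyl chain or a phenyl ring carrying a carboxylic acid might behave differently. On these data alone, it also remains open whether the same 4-methoxyphenyl would change anything on the cores of compound 2 and compound 3.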